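This account rests on a few compounds, and the source may have more. Where it says the series, first, only, none or still open, it means among the compounds named here.

The shared core appears in three compounds. Compound 1, `CC1(C)CN(C2=CCCC2=O)c2cc(N)ccc2S1`, carries an amino group on its aromatic ring, and in a functional assay on aorta (Rattus norvegicus, strain Wistar), in the presence of a further agent that is not named here (a higher number here means a larger maximal response, a lower number a smaller maximal response), compound 1 is recorded as "not determined" (no result reported). Compound 2, `Cc1ccc2c(c1)N(C1=CCCC1=O)CC(C)(C)S2`, carries a methyl group instead, and in this assay compound 2 gives 78%. Within the numbers shown, compound 2 thus stands as the only compound with a measured maximal response; the one further entry, compound 1, offers no single number to set beside it.

Compound 3, `CC1(C)CN(C2=CCCC2=O)c2ccccc2S1`, has not yet been tested in this assay. It differs from compound 2 in one place: hydrogen in place of methyl on an aromatic carbon. Within the data shown here, no measured pair in this set separates only by such a change, so the size of this step cannot be read from the data and has to be estimated. Given that only the small methyl group leaves and a hydrogen enters, compound 3 is expected to differ from compound 2 by no more than the usual scatter, with the expected step of a number 3 percentage points lower from compound 2 to compound 3 (within the scatter) in no definite direction. Compound 3 is therefore estimated to reach 75% in this assay, within a range of 60% to 90%.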

Compound 3, largest response reached (Emax), in percent of the reference or control that the assay uses: 61%
Estimate against measurement, compound 3: 14 percentage points above; the measured number falls inside the stated range.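

In this assay, hydrogen in place of methyl on this aromatic carbon, meta to a fused ring and para to a fused ring, gives a number 17 percentage points lower from compound 2 to compound 3 (beyond the scatter). Among these compounds, this is the first measured pair in the set, and it shows that a change of a single carbon atom at this place can shift the maximal response by more than the usual scatter, so the methyl group and the hydrogen cannot be treated as interchangeable here. Nothing available explains the drop, which stands as an observation without a known cause.

Any step involving the amino group of compound 1 cannot be read, so the pair shows the effect of methyl only against hydrogen and gives no trend across several groups at this place. As far as these compounds go, it remains open whether an ethyl group, a methoxy group, a chlorine atom or a carboxylic acid on the same aromatic carbon would follow the methyl group or the hydrogen, and whether a methyl group on another carbon of the same ring would produce a step of similar size.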